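This account rests on a few compounds, and the source may have more. Where it says the series, first, only, none or still open, it means among the compounds named here.

The series shares one core; compound 1 `Cc1ccc(NC2=CC(=O)c3nc4n(c3C2=O)[C@H]2OC[C@@H](O)[C@H]2OC4)cc1`, compound 2 `O=C1C(NC2CC2)=CC(=O)c2c1nc1n2[C@H]2OC[C@@H](O)[C@H]2OC1` and compound 3 `O=C1C=C(NC2CCCCC2)C(=O)c2c1nc1n2[C@H]2OC[C@@H](O)[C@H]2OC1` carry different groups on an amine nitrogen. In a functional assay on HeLa cells (Homo sapiens) for inhibition, read by sulforhodamine B assay (a higher number here means a weaker inhibitor, a lower number a stronger inhibitor), compound 1 gives 3860 nM. For compound 2 the assay reports only a limit, > 16000 nM. For compound 3 likewise only a limit is reported, > 16000 nM. Compound 2 thus stands at the limit shared by two of the three values given (the limit of > 16000 nM in this assay, at which 2 of the 3 values shown sit), with no number of its own. Compound 4 `O=C1C(NC2CCCCC2)=CC(=O)c2c1nc1n2[C@H]2OC[C@@H](O)[C@H]2OC1`, not yet measured, differs from compound 2 by cyclohexyl in place of cyclopropyl on an amine nitrogen. Among the compounds with values here, no measured step follows this exact change. Within the data shown here, the one measured step bearing on a cyclohexyl on the amine nitrogen, an at least 4.1-fold higher number from compound 1 to compound 3 (0.61 log units; beyond the scatter), runs to a limit. Compound 3 also carries a cyclohexyl on an amine nitrogen and sits at that limit. From this, the step to compound 4 is expected to stay within the limit region, a step that the limit leaves unreadable from compound 2 to compound 4. The estimate for compound 4 in this assay is 25000 nM, expected between 8000 nM and 60000 nM.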

Compound 4, half-maximal inhibitory concentration: > 16000 nM
Compound 4 gave a limit, no number (the forecaster's own chance of this, stated with the estimate: 75%); the middle value lies beyond the limit too.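

In this assay compound 4 gives only a limit, > 16000 nM, and compound 2 also stands at a limit, so no step can be read between compound 2 and compound 4. The compounds shown leave open how cyclopropyl and cyclohexyl compare on the amine nitrogen, with most values stopping at the same limit: the limit of > 16000 nM in this assay, at which 3 of the 4 values shown sit.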